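Inverting One Stereocentre in a Potent Amide

This account rests on a few compounds, and the source may have more. Where it says the series, first, only, none or still open, it means among the compounds named here.

In a functional assay on HOS-TE85 cells (Homo sapiens) for inhibition, read by CCK-8 assay, with a stated time of 72 h (a higher number here means a weaker inhibitor, a lower number a stronger inhibitor), compound 1 `Cc1ccnc(N2C(=O)CS[C@@H]2c2cccc(C(=O)NCCCCn3cccn3)c2)c1` gives 21.9 nM and compound 2 `CC(F)(F)c1cccc(N2C(=O)CSC2c2cccc(C(=O)NCCCCc3ccccc3)c2)c1` gives 29.1 nM as two values within the usual scatter of each other. Compound 3 `COc1ccccc1N1C(=O)CSC1c1cccc(C(=O)NCCCCN2CCN(C(=O)OC(C)(C)C)CC2)c1` is reported only as a limit of > 1000 nM and not as a number. Compound 4 `Cc1ccnc(N2C(=O)CS[C@H]2c2cccc(C(=O)NCCCCn3cccn3)c2)c1` has the same atoms and bonds as compound 1 and differs only in configuration by the two compounds have the same atoms and bonds and differ only in configuration as drawn: 1 of 1 stereo elements differ; a stereocentre at a saturated ring carbon is drawn R in compound 1 and S in compound 4 at a saturated ring carbon, where a stereocentre drawn R in compound 1 is drawn S in compound 4. Among the compounds with values here, no measured pair shows what such a change does in this assay so any expectation is wide. The expected 5.5-fold higher number from compound 1 to compound 4 (0.74 log units; beyond the scatter) points toward weaker inhibition, though a change within the scatter remains possible. For compound 4 the estimated value is 120 nM with an expected span from 10 nM to 1000 nM as its range.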

Compound 4, half-maximal inhibitory concentration: > 10000 nM
Compound 4: no number, only a limit (the forecaster's own chance of this, stated with the estimate: 15%); at least 83-fold (1.92 log units) between middle value and limit.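

In this assay, the configuration at the saturated ring carbon proves decisive, as inverting it from R to S gives an at least 450-fold higher number from compound 1 to compound 4 (2.65 log units; beyond the scatter). Compound 4 is reported only as a limit, > 10000 nM. The loss can be assigned to this stereocentre alone because nothing else changes: the fact that compounds 1 and 4 differ only in the configuration as drawn

From the compounds shown here alone, whether the same preference holds for compound 2 and compound 3, both drawn without a configuration at this carbon, stays open. Also open, going by these compounds, is whether the R configuration keeps its advantage with a carboxylic acid on the amide side chain.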